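Thiazolopyrimidine series: para substituent swap, methylsulfonyl to carboxy

A few compounds are considered here, and "the series" means these few. Any claim that something is new, unique, unknown or untested is made for them only; others in the source may bear on it.

Measured compounds:
compound 1 `Clc1cccc(Cl)c1Nc1nc2c(Nc3ccccc3)ncnc2s1` 176 nM
compound 2 `Cc1ccc(Nc2ncnc3sc(Nc4c(Cl)cccc4Cl)nc23)cc1` 33 nM
compound 3 `CS(=O)(=O)c1ccc(Nc2ncnc3sc(Nc4c(Cl)cccc4Cl)nc23)cc1` 5 nM

In a functional assay on HEK293 cells for antagonist activity at transient receptor potential cation channel subfamily V member 1 (Homo sapiens), read by calcium flux (a lower number here means a stronger inhibitor, a higher number a weaker inhibitor), compound 3 gives the lowest number of the three, compound 2 the nearest and compound 1 the furthest; both gaps lie beyond the scatter. The measured steps all concern the same aromatic carbon: a 5.3-fold lower number from compound 1 to compound 2 (0.73 log units; beyond the scatter), a 35-fold lower number from compound 1 to compound 3 (1.55 log units; beyond the scatter) and a 6.6-fold lower number from compound 2 to compound 3 (0.82 log units; beyond the scatter). Each group that replaced hydrogen there gave a lower number, and the methylsulfonyl group gave the lowest.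

Compound 4 `O=C(O)c1ccc(Nc2ncnc3sc(Nc4c(Cl)cccc4Cl)nc23)cc1` differs from compound 3 by carboxy in place of methylsulfonyl on an aromatic carbon. Among the compounds with values here, no measured step covers the carboxy group, so nothing shows directly how it compares with methylsulfonyl. What the three steps show is that this position moves the number strongly, and that compound 3 sits at the low end of what has been seen, so a move away from it is more likely upward than downward. Compound 4 is therefore expected to give a somewhat higher number, a 6.0-fold higher number from compound 3 to compound 4 (0.78 log units; beyond the scatter), with the estimate at 30 nM and a range of 5 nM to 200 nM.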

Compound 4, half-maximal inhibitory concentration: > 5000 nM
Compound 4: a limit, no number (the forecaster's own chance of this, stated with the estimate: 5%); middle value at least 160-fold (2.22 log units) from the limit.
By their numbers in this assay, from the lowest: compound 3; then compound 2; then compound 1. At a limit, above all of these: compound 4.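

In this assay compound 4 gives > 5000 nM, which is a limit and not a number, so every step to it is a bound: the limit of > 5000 nM in this assay, at which 1 of the 4 values shown sits.

The earlier compounds shown here showed only lower numbers when a group replaced hydrogen on this aromatic carbon, whereas carboxy reverses that direction, with the largest step against methylsulfonyl (an at least 1000-fold higher number from compound 3 to compound 4 (3.00 log units; beyond the scatter)) and a large one against methyl (an at least 150-fold higher number from compound 2 to compound 4 (2.18 log units; beyond the scatter)). Even the unsubstituted compound does better (an at least 28-fold higher number from compound 1 to compound 4 (1.45 log units; beyond the scatter)), so compound 4 goes against the pattern of the other three, and a substituent at this place can cost far more than the earlier steps gained.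

The compounds shown leave open how a methyl ester or a primary amide on this carbon would compare with carboxy. They also leave open where an amine would fall.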